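The compounds below may be only part of what the source reports. "The series", "measured", "known", "first", "only" and "open" are said of these compounds alone.

Notes on the series. The compounds share the core seen in compound 1, `CCc1cc(N2CC[C@@H](C)[C@@H](N(C)c3ncnc4[nH]ccc34)C2)n2ncnc2n1`, which is varied at one position of the triazolopyrimidine part. Compound 2 is `Cc1cc(N2CC[C@@H](C)[C@@H](N(C)c3ncnc4[nH]ccc34)C2)n2nc(SCc3cc(Cl)ccc3Cl)nc2n1` and compound 3 is `C=CCSc1nc2nc(C)cc(N3CC[C@@H](C)[C@@H](N(C)c4ncnc5[nH]ccc45)C3)n2n1`; compound 4, `Cc1cc(N2CC[C@@H](C)[C@@H](N(C)c3ncnc4[nH]ccc34)C2)n2nc(SCc3ccccc3)nc2n1`, is not yet measured.

In a toxicity assay on GES1 cells (Homo sapiens) for inhibition, read by MTT assay, with a stated time of 72 h (a higher number here means a weaker inhibitor, a lower number a stronger inhibitor), compound 1 gives > 100000 nM, which is a limit of the assay and not a number. In this assay compound 2 gives 87500 nM. Compound 3 also reaches only a limit, > 100000 nM, so compound 3 stands at the ceiling of the measured range and no number is known for it. Among the measured compounds shown here, the one measured step, an at least 1.1-fold higher number from compound 2 to compound 3 (0.05 log units; that floor lies within the scatter), is the only step that bears on the change to compound 4; it is small and its floor lies within the scatter, and the limit of > 100000 nM in this assay, at which 2 of the 3 values shown sit, shows how little the series moves.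

The change from compound 3 to compound 4 is phenyl in place of vinyl on a saturated chain carbon bound to a sulfur. Given the small step from compound 2 to compound 3, the expected step of a number no higher from compound 3 to compound 4 (the limit leaves the size open) is none beyond the scatter. The estimate for compound 4 in this assay is 100000 nM, expected within 40000 nM to 300000 nM, with a good chance that only a limit is reported.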

Compound 4, half-maximal inhibitory concentration: 67200 nM
The estimate for compound 4 lay 1.5-fold (0.17 log units) above the measured number; the range from low to high includes it.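

Compound 4 gives a number in this assay where the allylsulfanyl compound 3 gives only a limit, so the benzylsulfanyl group is the second group at this position, after the 2,5-dichlorobenzyl group of compound 2, to return a measurable value. The change from vinyl to phenyl on the saturated chain carbon bound to a sulfur reads as an at least 1.4-fold lower number from compound 3 to compound 4 (0.17 log units; that floor lies within the scatter), so this swap shows no step beyond the scatter, although the limit means that its true size is not fixed. Among the compounds shown here, the comparison of the two aromatic groups, a 1.3-fold lower number from compound 2 to compound 4 (0.11 log units; within the scatter), adds what the earlier compounds could not show: in this assay, phenyl and 2,5-dichlorophenyl at this place cannot be told apart, so the two chlorines show no effect on the read-out here.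

As far as these compounds go, how far the values of the series extend past the ceiling stays unknown, and the size of every step that involves compound 3 remains open: the limit of > 100000 nM in this assay, at which 2 of the 4 values shown sit. Also open, from the compounds shown here alone, is whether an amine, a carboxylic acid or a longer chain in place of phenyl on the same carbon would move the number beyond the scatter.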